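A few compounds are considered here, and "the series" means these few. Any claim that something is new, unique, unknown or untested is made for them only; others in the source may bear on it.

Of the compounds shown here, three built on a shared core have been measured in a functional assay on HT-29 cells (Homo sapiens) for inhibition; a lower number here means a stronger inhibitor of growth, a higher number a weaker inhibitor of growth. Compound 1 `O=C(/C=C/c1cccc(O)c1)c1cccc(-n2cc(-c3ccccc3)[nH]c2=O)c1` gives 3330 nM. Compound 2 `O=C(/C=C/c1cccc(O)c1)c1cccc(-n2cc(-c3ccc(Cl)cc3)[nH]c2=O)c1`, which carries a chloro in place of hydrogen on an aromatic carbon, gives 1900 nM, and the step of a 1.8-fold lower number from compound 1 to compound 2 (0.24 log units; within the scatter) stays within the scatter. Compound 3 `COc1cc(/C=C/C(=O)c2cccc(-n3cc(-c4ccccc4)[nH]c3=O)c2)cc(OC)c1OC` gives 660 nM, the lowest of the three numbers; its gaps to compound 2 and to compound 1 both lie beyond the scatter, so compound 3 is the strongest inhibitor of growth among them.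

Compound 4 `COc1ccc(-c2cn(-c3cccc(C(=O)/C=C/c4cc(OC)c(OC)c(OC)c4)c3)c(=O)[nH]2)cc1` differs from compound 3 by methoxy in place of hydrogen on an aromatic carbon. Among the measured compounds shown here, the one measured step that bears on this, the swap of a hydrogen for a chloro on an aromatic carbon para to a large group, is a 1.8-fold lower number from compound 1 to compound 2 (0.24 log units; within the scatter), a small change. For the measured compounds named here, no step with a methoxy group has been measured, so the expectation rests on that single step alone. Compound 4 is therefore expected to show a step of a 1.2-fold lower number from compound 3 to compound 4 (0.08 log units; within the scatter) in this assay, without a clear direction beyond the scatter. The estimated value for compound 4 is 550 nM, in a range from 200 nM to 1500 nM.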

Compound 4, concentration for 50% growth inhibition: 1280 nM
Compound 4: middle estimate off by 2.3-fold (0.37 log units), on the low side; low and high end bracket the measured number.
By their numbers in this assay, from the lowest: compounds 3, 4, 2 and 1 (each within the scatter of the next, the first and the last beyond it).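

In this assay, the change from phenyl to 4-methoxyphenyl gives a 1.9-fold higher number from compound 3 to compound 4 (0.29 log units; within the scatter) and so cannot be told apart from no change at this aromatic carbon para to a large group. Together with a 1.8-fold lower number from compound 1 to compound 2 (0.24 log units; within the scatter) as the only other step here, it shows that neither chloro nor methoxy at this position moves the number beyond the scatter, although the two changes were made on different versions of the shared core. No measurement is available that could explain the size of either step.

From the compounds shown here alone, it remains open whether methoxy would give a similar result on the core of compound 1, where the chloro step was read. Going by these compounds, it also remains open whether an amine or a carboxylic acid at this same carbon would move the number beyond the scatter.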